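The compounds below may be only part of what the source reports. "The series", "measured", "known", "first", "only" and "open" are said of these compounds alone.

Measured so far:
compound 1 `COc1ccc(C(=O)/C=C/c2ccc(F)cc2)c2c1C=CC(C)(C)O2`: > 10000 nM
compound 2 `COc1ccc(C(=O)/C=C/c2ccc3ccccc3n2)c2c1C=CC(C)(C)O2`: 3790 nM

Of the compounds shown here, two built on a shared core have been tested in a functional assay on HT-29 cells (Homo sapiens) for antiproliferative activity, read by MTT assay, with a stated time of 24 h; on this read-out higher numbers stand for weaker inhibition and lower numbers for stronger inhibition. In this assay compound 1 gives > 10000 nM, and that figure is a limit of the assay rather than a measured number. Compound 1 thus stands at the limit of > 10000 nM in this assay, at which 1 of the 2 values shown sits. Compound 2, which carries a different aryl group on the same core, gives 3790 nM in this assay, a number inside the measured range. Among the measured compounds shown here, no single-point step connects compound 1 and compound 2, so their two values can only be read side by side.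

Compound 3 `COc1ccc(C(=O)/C=C/c2ccc([N+](=O)[O-])cc2)c2c1C=CC(C)(C)O2` is not yet measured. It differs from compound 1 by nitro in place of fluoro on an aromatic carbon. No measured step covers this change, and the shown values give no direction for it. The expected step is an at least 1.4-fold lower number from compound 1 to compound 3 (0.15 log units; that floor lies within the scatter), with wide uncertainty. For compound 3 the estimate in this assay is 7000 nM, in a range from 1500 nM to 30000 nM.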

Compound 3, half-maximal inhibitory concentration: 3730 nM
Compound 3: middle estimate off by 1.9-fold (0.27 log units), on the high side; measured number inside the range.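

Among the compounds shown here, replacing fluoro with nitro gives the first single-change comparison on the shared core: in this assay, going from 4-fluorophenyl to 4-nitrophenyl produces an at least 2.6-fold lower number from compound 1 to compound 3 (0.42 log units; beyond the scatter). This shows that the read-out responds to the group at this position, and by more than repeated measurements would scatter. Compound 1 gives > 10000 nM, which is a limit of the assay, so the step has only a floor and its full size stays unknown: the limit of > 10000 nM in this assay, at which 1 of the 3 values shown sits.

With only fluoro and nitro compared at this position, the data cannot tell which feature of the nitro group goes with the lower number. From the compounds shown here alone, whether an amine, a nitrile or a carboxylic acid in the same place would move the number in the same direction, and how far, remains open.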